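The source may hold more compounds than are shown below. What is called first, only, known or untested is meant among the compounds shown, and "the series" means these compounds.

Of the compounds shown here, three have already been measured in a functional assay on B16-F0 cells (Mus musculus) for inhibition, read by CCK-8 assay, with a stated time of 48 h (on this read-out lower numbers stand for stronger inhibition and higher numbers for weaker inhibition), and a fourth awaits testing. Compound 1, `COc1cc(-c2ccnc3cc(-c4cn(CO)c5ccccc45)nn23)cc(OC)c1OC`, gives 93 nM in this assay. Compound 2, `COc1cc(-c2cc3nccc(-c4c[nH]c5ccccc45)n3n2)cc(OC)c1OC`, reaches only the limit of this assay, > 10000 nM, which marks a boundary of the test rather than a number. Compound 3, `COc1cc(-c2ccnc3cc(-c4cccc(C#N)c4)nn23)cc(OC)c1OC`, likewise reaches only the limit, > 10000 nM, so no numeric potency is known for it. Two of the three values shown sit at that boundary, as summarised by the limit of > 10000 nM in this assay, at which 2 of the 3 values shown sit, and compound 3 therefore stands among the compounds whose inhibition could not be quantified, while compound 1 alone gives a measured number.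

Compound 4, `COc1cc(-c2ccnc3cc(-c4ccc5cnn(C)c5c4)nn23)cc(OC)c1OC`, differs from compound 3 in a single place: 1-methyl-1H-indazol-6-yl in place of 3-cyanophenyl on an aromatic carbon. Within the data shown here, the group that enters is a fused aromatic system, and compound 1, the only compound with a numeric value, also carries a fused aromatic group on the shared core rather than a single six-membered ring. Among the measured compounds shown here, no step of exactly this kind has been measured, so the size of the change can only be estimated. A gain in inhibition beyond the usual scatter is expected, an at least 16-fold lower number from compound 3 to compound 4 (1.22 log units; beyond the scatter). Compound 4 is accordingly estimated at 600 nM, with a plausible range from 60 nM to 8000 nM.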

Compound 4, half-maximal inhibitory concentration: 1000 nM
Compound 4: middle estimate off by 1.7-fold (0.22 log units), on the low side; low and high end bracket the measured number.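

Compound 3 gives > 10000 nM in this assay, which is a limit and not a number, and such limits make up much of this small set: the limit of > 10000 nM in this assay, at which 2 of the 4 values shown sit. Putting 1-methyl-1H-indazol-6-yl in place of 3-cyanophenyl gives an at least 10-fold lower number from compound 3 to compound 4 (1.00 log units; beyond the scatter), so the true gain may be larger than this figure, but it is clearly more than ordinary variation between repeat measurements. With the rest of the shared core unchanged, this shows that the group on this aromatic carbon of a five-membered aromatic ring with 2 nitrogen can decide whether inhibition is measurable at all in these cells.

This single swap changes several things at once, including the second aromatic ring, the ring nitrogens, the methyl group and the loss of the nitrile, so it cannot show which of them matters. On these data alone, it also remains open how this place would respond to a plain phenyl ring, or to a ring carrying an amine or a carboxylic acid.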